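The compounds below may be only part of what the source reports. "The series", "measured", "known", "first", "only" and "open" are said of these compounds alone.

Values in an ADME assay on L02 cells (Homo sapiens) for inhibition, read by CCK-8 assay, with a stated time of 48 h; a higher number here means a weaker inhibitor of growth, a lower number a stronger inhibitor of growth:
- compound 1 `Cc1ccccc1Nc1nc(NC2CC2)ncc1Cl`: > 100000 nM (a limit of the assay)
- compound 2 `Cc1ccccc1Nc1nc(Nc2ccccn2)ncc1Cl`: 6150 nM
- compound 3 `Cc1ccccc1Nc1nc(Nc2ccc(N3CCN(C)CC3)cn2)ncc1Cl`: not yet measured

Within the data shown here, compound 2, at 6150 nM, holds the only actual number. The change under study is 4-methylpiperazin-1-yl in place of hydrogen on an aromatic carbon. Among the measured compounds shown here, only one measured step bears on it, and only indirectly: an at least 16-fold lower number from compound 1 to compound 2 (1.21 log units; beyond the scatter), which is large but exchanged the whole group on that nitrogen. For the measured compounds named here, with no measured step for this kind of change, a modest move to a lower number is expected, and the expected step is a 2.1-fold lower number from compound 2 to compound 3 (0.31 log units; beyond the scatter). Compound 3 is estimated at 3000 nM, with an expected range of 600 nM to 15000 nM.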

Compound 3, concentration for 50% growth inhibition: 5980 nM
Compound 3: middle estimate off by 2.0-fold (0.30 log units), on the low side; low and high end bracket the measured number.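

In this assay, 4-methylpiperazin-1-yl in place of hydrogen on an aromatic carbon, two atoms from the ring nitrogen, gives a 1.0-fold lower number from compound 2 to compound 3 (0.01 log units; within the scatter), so the two values cannot be told apart. Among these compounds, this carbon therefore takes a group of this size with no readable effect in this assay, whereas the one earlier step, at the nitrogen, was large. Nothing measured here accounts for this result. Going by these compounds, whether an amine, a carboxylic acid or a longer chain on the same carbon would read alike remains open.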